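A few compounds are considered here, and "the series" means these few. Any claim that something is new, unique, unknown or untested is made for them only; others in the source may bear on it.

Three measured compounds share one core and differ only in the chain attached to the carbonyl: compound 1 `CCc1nn(CCCN2CCN(c3ccc(C)cc3)CC2)c(=O)c(N)c1C(C)=O`, compound 2 `CCC(=O)c1c(C)nn(CCCN2CCN(c3ccc(C)cc3)CC2)c(=O)c1N` and compound 3 `CCCC(=O)c1c(C)nn(CCCN2CCN(c3ccc(C)cc3)CC2)c(=O)c1N`. In a functional assay on the whole organism (Abdomen, strain Swiss) for inhibition, with Mus musculus as the target, with stated times of 30 min, 10 min and 5 min, at a dose of 40 mg/kg by the oral route (a higher number here means a stronger effect of the compound at the dose given, a lower number a weaker effect), compound 1 gives 41%, compound 2 gives 29%, and compound 3 gives 32%. Compound 3 stands second highest of the three numbers, with compound 2 nearest and lower and compound 1 furthest and higher, both gaps within the usual scatter, so no order among them can be claimed. Within the data shown here, the one measured step of the same kind, a number 3 percentage points higher from compound 2 to compound 3 (within the scatter), also lies within the scatter.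

Compound 4 `CCCCC(=O)c1c(C)nn(CCCN2CCN(c3ccc(C)cc3)CC2)c(=O)c1N` is not yet measured. It differs from compound 3 by methyl in place of hydrogen on a saturated chain carbon, three bonds along the chain from a carbonyl carbon; read one bond further out, the change is propyl to butyl, the same lengthening of the chain already seen from compound 2 to compound 3. Because that step, a number 3 percentage points higher from compound 2 to compound 3 (within the scatter), stayed within the scatter, the expected step of a number 1 percentage points higher from compound 3 to compound 4 (within the scatter) is likewise expected to be no larger than the scatter, in either direction. Compound 4 is therefore estimated to give 33% in this assay, with a range from 20% to 46%.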

Compound 4, a percentage reported as inhibition, in the whole organism at one dose (the size of the read-out at that dose, not a potency): 15%
Estimate against measurement, compound 4: 18 percentage points above; measured number below the stated range.
By their numbers in this assay, from the lowest: compound 4; then compounds 2, 3 and 1 (each within the scatter of the next, the first and the last beyond it).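

In this assay, the change of propyl to butyl on the carbonyl gives a number 17 percentage points lower from compound 3 to compound 4 (beyond the scatter), whereas ethyl to propyl gave only a number 3 percentage points higher from compound 2 to compound 3 (within the scatter). Measured against the ethyl end of the chain, the same loss holds, with a number 14 percentage points lower from compound 2 to compound 4 (beyond the scatter), so among compounds 2, 3 and 4 the added carbon three bonds along the chain from the carbonyl carbon is the one that makes a readable difference, and lengthening does not act evenly along this chain. Nothing measured on these compounds bears on why the effect falls at butyl.

From the compounds shown here alone, whether a longer chain such as pentyl lowers the number further or leaves it at the level of compound 4 remains open. Equally open, going by these compounds, is whether a branched chain such as isobutyl, or a hydroxyl or an amine on that same carbon, would behave as the added methyl does.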